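Chloro to bromo on the fused ring of compound 1

The source may hold more compounds than are shown below. What is called first, only, known or untested is meant among the compounds shown, and "the series" means these compounds.

Compound 1 `O=c1oc2ccc(Cl)cc2cc1-c1cn2nc(-c3c([O-])[o+]nn3-c3ccc(Cl)cc3)sc2n1` gives 8 ug/mL in a functional assay on HT-29 cells (Homo sapiens) for cytotoxicity, read by sulforhodamine B assay (on this read-out higher numbers stand for weaker inhibition of growth and lower numbers for stronger inhibition of growth), the highest of the three measured numbers. Compound 2 `O=c1oc2ccc(Cl)cc2cc1-c1cn2nc(-c3c([O-])[o+]nn3-c3ccccc3)sc2n1` gives 7.7 ug/mL, and compound 3 `COc1ccc(-n2n[o+]c([O-])c2-c2nn3cc(-c4cc5cc(Cl)ccc5oc4=O)nc3s2)cc1` gives 3.68 ug/mL. The step to compound 4 `O=c1oc2ccc(Br)cc2cc1-c1cn2nc(-c3c([O-])[o+]nn3-c3ccc(Cl)cc3)sc2n1` is bromo in place of chloro on an aromatic carbon. Among the measured compounds shown here, no measured step swaps one halogen for another; the nearest comparisons are a 1.0-fold lower number from compound 1 to compound 2 (0.02 log units; within the scatter) and a 2.2-fold lower number from compound 1 to compound 3 (0.34 log units; beyond the scatter), with the chloro-to-hydrogen change staying within the scatter and only the methoxy change reaching a modest shift. A chloro-to-bromo exchange is expected to give no step beyond the scatter, no change at the digits printed from compound 1 to compound 4 (within the scatter). Compound 4 is therefore estimated at 8 ug/mL, with a range from 4 ug/mL to 16 ug/mL in this assay.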

Compound 4, concentration for 50% growth inhibition: 5.25 ug/mL
The estimate for compound 4 lay 1.5-fold (0.18 log units) above the measured number, and the stated range covers the measured number.
By their numbers in this assay, from the lowest: compounds 3, 4, 2 and 1 (each within the scatter of the next, the first and the last beyond it).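

Among the compounds shown here, compounds 1, 2 and 3 all carry chloro at this position, so compound 4 gives the first reading of a change here. In this assay, bromo in place of chloro gives a 1.5-fold lower number from compound 1 to compound 4 (0.18 log units; within the scatter), so this one halogen exchange on the fused system leaves the number within the scatter. Nothing available explains this step.

From the compounds shown here alone, whether an amine or a carboxylic acid at this position would move the number beyond the scatter stays open. So does whether the exchange gives the same result alongside the methoxy group of compound 3.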